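Losing the pyrrole from the most lipophilic compound

The source may hold more compounds than are shown below. What is called first, only, known or untested is meant among the compounds shown, and "the series" means these compounds.

Compound 1 `CCOc1cc(Cl)c(C(=O)NC(=O)Nc2nc3ccc(S(=O)(=O)C4CCN(C)CC4)cc3s2)cc1-n1cccn1`: 3
Compound 2 `CN1CCC(S(=O)(=O)c2ccc3nc(NC(=O)NC(=O)c4cc(-n5cccn5)ccc4Cl)sc3c2)CC1`: 2.3
Compound 3 `CCOc1cc(Cl)c(C(=O)NC(=O)Nc2nc3ccc(CN4CCN(C)CC4)cc3s2)cc1-n1cccc1`: 4
Compound 4 `CCOc1ccc(C(=O)NC(=O)Nc2nc3ccc(CN4CCN(C)CC4)cc3s2)c(Cl)c1`: not yet measured

In a physicochemical assay for lipophilicity, at pH 7.4 (a higher number here means a more lipophilic compound, a lower number a more polar compound), compound 3 stands highest of the three, at 4. Compound 4 differs from it in one place, where hydrogen takes the place of 1H-pyrrol-1-yl on an aromatic carbon: hydrogen in place of 1H-pyrrol-1-yl on an aromatic carbon. For the measured compounds named here, only one measured step bears on this: a number 0.70 log units lower from compound 1 to compound 2 (beyond the scatter), a modest fall when hydrogen took the place of ethoxy on an aromatic carbon. The group leaving there is a different one, so that step is only a rough guide. A fall of similar size is expected here, and the estimated step is a number 0.80 log units lower from compound 3 to compound 4 (beyond the scatter). Compound 4 is estimated at 3.2, with an expected range from 2.6 to 3.8.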

Compound 4, distribution coefficient: 3.4
Beside the measured number, compound 4's estimate is 0.20 log units below it; measured number inside the range.
By their numbers in this assay, from the lowest: compound 2; then compound 1; then compound 4; then compound 3.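

In this assay, taking the 1H-pyrrol-1-yl group off this aromatic carbon, ortho to an ethoxy group, gives a number 0.60 log units lower from compound 3 to compound 4 (beyond the scatter), a modest step beyond the scatter. So a whole five-membered aromatic ring can leave this position with the ethoxy group kept, and the number still falls. No measurement here explains that fall. Going by these compounds, what remains open is how an amine or a carboxylic acid at this carbon would read in this assay, and whether losing the 1H-pyrrol-1-yl group would give a similar step on a different core.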